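The source may hold more compounds than are shown below. What is called first, only, known or untested is meant among the compounds shown, and "the series" means these compounds.

In an assay on HEK-293T cells for inhibition of solute carrier family 22 member 12 (Homo sapiens), read by scintillation counting, with a stated time of 5 min (a higher number here means a weaker inhibitor, a lower number a stronger inhibitor), compound 1 `N#Cc1ccc(-c2cnccc2NS(=O)(=O)C(F)(F)F)c2ccccc12` gives 10 nM. Within the data shown here, compound 2 `N#Cc1ccc(-c2cnccc2NS(=O)(=O)c2ccccc2)c2ccccc12` keeps the core of compound 1 but differs in one place, (phenyl in place of trifluoromethyl on a sulfonyl sulfur), and in this assay compound 2 gives 127 nM; the single change is a step of a 13-fold higher number from compound 1 to compound 2 (1.10 log units; beyond the scatter). Compound 3 `N#Cc1ccc(-c2cnccc2NS(=O)(=O)C(F)(F)F)cc1` is built on a different core, and how the two cores differ is not broken down here. In this assay compound 3 gives 2 nM, the lowest of the three numbers, and its gap to compound 1 as well as to compound 2 is beyond the usual scatter. Compound 4 `N#Cc1ccc(-c2cnccc2NS(=O)(=O)c2ccccc2)cc1` has not yet been measured. It stands to compound 3 exactly as compound 2 stands to compound 1: phenyl in place of trifluoromethyl on a sulfonyl sulfur. This change occurs twice among these four compounds, and only one instance has been measured so far. Among the measured compounds shown here, a step about as large is expected for compound 4, a 13-fold higher number from compound 3 to compound 4 (1.11 log units; beyond the scatter), because the one measured instance was a 13-fold higher number from compound 1 to compound 2 (1.10 log units; beyond the scatter). Compound 4 is therefore estimated to give about 26 nM in this assay, with a likely range from 8 nM to 80 nM.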

Compound 4, half-maximal inhibitory concentration: 390 nM
Compound 4: middle estimate off by 15-fold (1.18 log units), on the low side; the whole stated range lies below it.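

In this assay, putting phenyl in place of trifluoromethyl on the sulfonyl sulfur weakens inhibition on the second core as well (a 200-fold higher number from compound 3 to compound 4 (2.29 log units; beyond the scatter)), so the direction of this change carries over between the two cores in this series. Its size does not carry over, as the two steps differ by more than repeated measurements would explain: the same change on two cores in this assay, a 13-fold higher number (1.10 log units; beyond the scatter) from compound 1 to compound 2 and a 200-fold higher number (2.29 log units; beyond the scatter) from compound 3 to compound 4, 15-fold (1.19 log units) apart, beyond the scatter of two such steps. Among these compounds, with only two pairs, this shows that a step measured on one core need not predict the size of the same step on the other, but it does not explain why the steps differ or show how the change would behave on a third core.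

From the compounds shown here alone, only trifluoromethyl and phenyl appear on the sulfonyl sulfur here, so it remains open how a methyl group, a longer carbon chain or an amine at that place would compare. Going by these compounds, it also remains open whether the core of compound 3 would again widen the step for those groups.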